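Notes on a one-carbon linker extension, compound 3 to compound 4

This account rests on a few compounds, and the source may have more. Where it says the series, first, only, none or still open, it means among the compounds named here.

Measured compounds:
Compound 1 `O[C@H]1Cc2ccccc2C1NC1CCN(CCCc2c[nH]c3ccc(-n4cnnc4)cc23)CC1` gives 37 nM in an assay on CHO cells for displacement of a labelled ligand from 5-hydroxytryptamine receptor 1D (Homo sapiens); a higher number here means a weaker inhibitor, a lower number a stronger inhibitor.
Compound 2 `c1ccc(CNC2CCN(CCCc3c[nH]c4ccc(-n5cnnc5)cc34)CC2)cc1` gives 4.6 nM in this assay.
Compound 3 `C[C@@H](NC1CCN(CCCc2c[nH]c3ccc(-n4cnnc4)cc23)CC1)c1ccccc1` gives 0.4 nM in this assay.

Compound 3 stands lowest of the three numbers. The nearest is compound 2, with a 12-fold lower number from compound 2 to compound 3 (1.06 log units; beyond the scatter); the furthest is compound 1, with a 93-fold lower number from compound 1 to compound 3 (1.97 log units; beyond the scatter). The remaining step, an 8.0-fold lower number from compound 1 to compound 2 (0.91 log units; beyond the scatter), also runs toward the benzylic amine substituent.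

Compound 4 `C[C@H](NCC1CCN(CCCc2c[nH]c3ccc(-n4cnnc4)cc23)CC1)c1ccccc1` differs from compound 3 by ((1-phenylethyl)amino)methyl in place of (1-phenylethyl)amino on a saturated ring carbon. The three measured steps all vary the group on the amine nitrogen and leave the link between that nitrogen and the saturated ring untouched; none of them bears directly on a one-carbon extension of that link. The strong gain from compound 2 to compound 3 shows that the region around the amine nitrogen is sensitive to small changes, so a shift of the amine away from the ring is not expected to be neutral. Among the measured compounds shown here, for compound 4 the expected step is a 3.8-fold higher number from compound 3 to compound 4 (0.57 log units; beyond the scatter), a moderate rise in this assay with wide uncertainty, since the change has no measured precedent here. Compound 4 is therefore estimated at 1.5 nM, within 0.3 nM to 8 nM.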

Compound 4, half-maximal inhibitory concentration: 4.4 nM
Compound 4: middle estimate off by 2.9-fold (0.47 log units), on the low side, and the stated range covers the measured number.
By their numbers in this assay, from the lowest: compound 3; then compounds 4 and 2 (each within the scatter of the next); then compound 1.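

In this assay, the link between the amine nitrogen and the saturated ring carbon proves as sensitive as the group on that nitrogen: the one-carbon extension gives an 11-fold higher number from compound 3 to compound 4 (1.04 log units; beyond the scatter), a loss of about the same size as the gain in a 12-fold lower number from compound 2 to compound 3 (1.06 log units; beyond the scatter). The extended amine shows no separation from the benzylamino amine, with a 1.0-fold lower number from compound 2 to compound 4 (0.02 log units; within the scatter), yet it still retains an 8.4-fold lower number from compound 1 to compound 4 (0.92 log units; beyond the scatter), so the 1-phenylethyl group on the longer link remains well ahead of the (2-hydroxy-2,3-dihydro-1H-inden-1-yl)amino group on the direct link. No measurement shown here accounts for the loss on extension, and its origin stays unassigned.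

The compounds shown leave open whether the benefit of the added methyl survives on the longer link, which a (benzylamino)methyl group would test, and whether a still longer chain, such as a (1-phenylethyl)aminoethyl group, would lose further. The structures of compound 3 and compound 4 are also drawn with opposite handedness at the 1-phenylethyl carbon, so the separate contributions of link length and handedness to this step remain unresolved.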